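Dichlorobenzimidazoles: nitro to amino at the anisole ring

A few compounds are considered here, and "the series" means these few. Any claim that something is new, unique, unknown or untested is made for them only; others in the source may bear on it.

Measured so far:
Compound 1, `COc1ccc(-c2nc3cc(Cl)c(Cl)cc3[nH]2)cc1`: 2500 nM
Compound 2, `COc1ccc(-c2nc3cc(Cl)c(Cl)cc3[nH]2)c([N+](=O)[O-])c1`: 28000 nM

Two compounds of the series have been run in an ADME assay on MDBK cells (Bos taurus) for cytotoxicity, read by MTT assay, with a stated time of 96 h; on this read-out lower numbers stand for higher toxicity in this test and higher numbers for lower toxicity in this test. Among the compounds with values here, compound 1 gives 2500 nM, and compound 2 gives 28000 nM; the single one-place step on record, an 11-fold higher number from compound 1 to compound 2 (1.05 log units; beyond the scatter), is nitro in place of hydrogen on an aromatic carbon. On the numbers shown, compound 2 stands highest of the two, with compound 1 as its nearest neighbour at a distance that clears the scatter.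

Compound 3, `COc1ccc(-c2nc3cc(Cl)c(Cl)cc3[nH]2)c(N)c1`, is the next compound to be measured in this assay. It differs from compound 2 as follows: amino in place of nitro on an aromatic carbon.

Within the data shown here, no measured step in this assay covers amino in place of nitro directly. Among the measured compounds shown here, the only step available, an 11-fold higher number from compound 1 to compound 2 (1.05 log units; beyond the scatter), says that the nitro group on this carbon moved the number a long way up from the hydrogen compound; compound 3 carries neither hydrogen nor nitro there, so the bearing of that step is indirect. The expected outcome is a number for compound 3 below compound 2 but not back to compound 1, an estimated step of a 3.1-fold lower number from compound 2 to compound 3 (0.49 log units; beyond the scatter), with wide uncertainty. Compound 3 is thus estimated at 9000 nM, within a range of 3000 nM to 30000 nM.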

Compound 3, half-maximal cytotoxic concentration: 6500 nM
Compound 3: the middle estimate sits 1.4-fold (0.14 log units) above what was measured, and the stated range covers the measured number.
By their numbers in this assay, from the lowest: compound 1; then compound 3; then compound 2.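

At this carbon, amino in place of nitro gives a 4.3-fold lower number from compound 2 to compound 3 (0.63 log units; beyond the scatter) in this assay, so the high number of compound 2 is not kept once the nitro group leaves. Amino in place of hydrogen still gives a 2.6-fold higher number from compound 1 to compound 3 (0.41 log units; beyond the scatter), which shows that a group other than nitro at this carbon can also raise the number over the hydrogen compound, though to a lesser extent, and places the three compounds in a clear order with hydrogen lowest, amino in the middle and nitro highest. Nothing at hand bears on why the three groups fall in this order.

From the compounds shown here alone, the order rests on three groups at one carbon of one core, so it remains open where a nitrile, a hydroxy group, an acetamide or a dimethylamino group at this carbon would fall relative to amino and nitro. Going by these compounds, it also remains open whether the same order would hold if the methoxy group gave way to a longer ether chain or a carboxylic acid.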